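Chloro in Place of Hydrogen on the Benzoyl Ring

This account rests on a few compounds, and the source may have more. Where it says the series, first, only, none or still open, it means among the compounds named here.

Three compounds have been measured in a functional assay on MDA-MB-231 cells (Homo sapiens) for inhibition, read by MTT assay, with a stated time of 48 h; a lower number here means a stronger inhibitor, a higher number a weaker inhibitor:

compound 1, `COc1ccc2c(c1)C/C(=C\c1cc(-c3cc(OC)c(OC)c(OC)c3)n[nH]1)C2=O`, 2000 nM
compound 2, `COc1cc(-c2cc(/C=C/C(=O)c3ccccc3)[nH]n2)cc(OC)c1OC`, 2300 nM
compound 3, `COc1cc2c(cc1OC)C(=O)/C(=C/c1cc(-c3cc(OC)c(OC)c(OC)c3)n[nH]1)C2`, 2500 nM

All three numbers lie within the scatter of one another, so none of them can be called the strongest or the weakest. Compound 2 stands between the other two; its nearest neighbour is compound 3 and its furthest is compound 1, and neither gap is beyond the scatter. Going by the values given here, the one step that can be read between measured compounds, a 1.3-fold higher number from compound 1 to compound 3 (0.10 log units; within the scatter), is likewise within the scatter.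

Compound 4, `COc1cc(-c2cc(/C=C/C(=O)c3ccc(Cl)cc3)[nH]n2)cc(OC)c1OC`, differs from compound 2 by chloro in place of hydrogen on an aromatic carbon. Among the compounds with values here, no measured pair shows a chloro entering in this assay, so nothing bears directly on this change; the only known step, from compound 1 to compound 3, concerns a methoxy and was within the scatter. On that thin basis compound 4 is expected to show no step beyond the scatter, a 1.2-fold lower number from compound 2 to compound 4 (0.06 log units; within the scatter). The estimate for compound 4 in this assay is therefore 2000 nM, with a range from 700 nM to 6000 nM.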

Compound 4, half-maximal inhibitory concentration: 26000 nM
The estimate for compound 4 lay 13-fold (1.11 log units) below the measured number; the whole stated range lies below it.
By their numbers in this assay, from the lowest: compounds 1, 2 and 3 (each within the scatter of the next); then compound 4.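

In this assay, going by these compounds alone, the numbers for the earlier compounds all lay within the scatter of one another, so they gave no sign that any single change could matter. Here, replacing one hydrogen with chloro on the benzoyl ring, para to a large group, gives an 11-fold higher number from compound 2 to compound 4 (1.05 log units; beyond the scatter) and so yields the first step beyond the scatter, showing that this position does not tolerate every change and that one heavy atom can be enough to weaken inhibition. No measurement shown here accounts for a step of this size.

The compounds shown leave open whether this loss is particular to chloro or would also follow from a fluoro or an amine at the same place. They also leave open whether chloro elsewhere on this ring would behave the same way.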